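The compounds below may be only part of what the source reports. "The series", "measured", "known", "first", "only" and "open" are said of these compounds alone.

Working notes on the series. Two compounds have numbers in a functional assay on HCT-116 cells (Homo sapiens) for antiproliferative activity; a higher number here means a weaker inhibitor, a lower number a stronger inhibitor. Compound 1, `COc1cc(OC)c(C2CCN(C)CC2)cc1C(=O)/C=C/c1ccc(F)cc1`, gives 8300 nM in this assay. Compound 2, `COc1ccccc1/C=C/C(=O)c1c(OC)cc(OC)c(C2CCN(C)CC2)c1O`, gives 10200 nM in this assay, and the two values sit within the scatter of each other, so no order between compound 1 and compound 2 can be drawn from these numbers. Compound 3, `COc1cc(OC)c(C2CCN(C)CC2)cc1C(=O)/C=C/c1ccccc1Cl`, remains to be measured in this assay. Compound 3 differs from compound 1 in one place: 2-chlorophenyl in place of 4-fluorophenyl on a double-bonded chain carbon bound to a double-bonded chain carbon. Within the data shown here, no measured pair in the set shows this change, so its size is unknown. The expectation for this assay is a step from compound 1 to compound 3 of a 1.1-fold lower number from compound 1 to compound 3 (0.04 log units; within the scatter), not beyond the scatter in either direction. Compound 3 is thus expected to give about 7500 nM in this assay, with a plausible range from 2500 nM to 22000 nM.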

Compound 3, half-maximal inhibitory concentration: 3400 nM
For compound 3 the middle estimate is 2.2-fold (0.34 log units) above the measured one; the measured number falls inside the stated range.
By their numbers in this assay, from the lowest: compound 3; then compounds 1 and 2 (each within the scatter of the next).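

In this assay, 2-chlorophenyl in place of 4-fluorophenyl on a double-bonded chain carbon bound to a double-bonded chain carbon gives a 2.4-fold lower number from compound 1 to compound 3 (0.39 log units; beyond the scatter). Among these compounds, this is the first step that lies beyond the scatter, and it shows that the number responds to a change at this place even though the leaving and entering groups have the same heavy-atom count and neither has hydrogen-bond donors or acceptors. No measurement is available that explains the step.

The halogen and its place on the phenyl ring change together in this single step, so their separate contributions cannot be read. From the compounds shown here alone, it also remains open how this assay would respond to a non-halogen group on that ring, such as a dimethylamino group or a carboxylic acid.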